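From Diethylamino to a Methylpiperazinyl Chain

A few compounds are considered here, and "the series" means these few. Any claim that something is new, unique, unknown or untested is made for them only; others in the source may bear on it.

Among the measured compounds shown here, compound 1 `CCN(CC)CCn1c(N)c(-c2nc3ccccc3[nH]2)c2nc(C#N)c(C#N)nc21` gives 7150 nM in a functional assay on HL60/MX2 cells (Homo sapiens) for antiproliferative activity, read by MTT assay, with a stated time of 48 h (a lower number here means a stronger inhibitor, a higher number a weaker inhibitor), the higher of the two numbers measured so far. Compound 2 `CN(C)CCCn1c(N)c(-c2nc3ccccc3[nH]2)c2nc(C#N)c(C#N)nc21` gives 2390 nM in this assay, and the step of a 3.0-fold lower number from compound 1 to compound 2 (0.48 log units; beyond the scatter) is the only measured one; it alters the same chain end that is now changed again. Compound 3 `CN1CCN(CCCn2c(N)c(-c3nc4ccccc4[nH]3)c3nc(C#N)c(C#N)nc32)CC1` differs from compound 1 by (4-methylpiperazin-1-yl)methyl in place of diethylamino on a saturated chain carbon, two bonds along the chain from an aromatic nitrogen. Because the earlier change at this chain end gave a 3.0-fold lower number from compound 1 to compound 2 (0.48 log units; beyond the scatter), a modest lowering is expected here as well. For compound 3 the expected step is a 2.4-fold lower number from compound 1 to compound 3 (0.38 log units; beyond the scatter). Compound 3 is thus estimated at 3000 nM, within 1200 nM to 7500 nM.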

Compound 3, half-maximal inhibitory concentration: 3320 nM
The estimate for compound 3 lay 1.1-fold (0.04 log units) below the measured number; measured number inside the range.
By their numbers in this assay, from the lowest: compounds 2 and 3 (each within the scatter of the next); then compound 1.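

In this assay, a ring-bearing chain end also gives a 2.2-fold lower number from compound 1 to compound 3 (0.33 log units; beyond the scatter), so the lowering seen with compound 2 is not confined to a small dimethylamino end. Replacing dimethylamino with 4-methylpiperazin-1-yl gives a 1.4-fold higher number from compound 2 to compound 3 (0.14 log units; within the scatter) and so does not separate these two chain ends. Nothing available explains these numbers.

Both steps from compound 1 change the amine and the chain together, so 3-(diethylamino)propyl would be needed to separate the two changes. Going by these compounds, whether morpholine or piperidine at this chain end would match compound 3 remains open.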